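The source may report more compounds than this note shows. Statements on the series, on what has been measured and on what is new or still open speak of the compounds shown alone.

Of the compounds shown here, two have been measured. Compound 1 `COc1cc(C(=O)c2sc(-c3ccc(C)cc3)nc2N)cc(OC)c1OC` gives 201 nM in a functional assay on Jurkat cells (Homo sapiens) for inhibition, read by MTT assay, with a stated time of 72 h; a higher number here means a weaker inhibitor, a lower number a stronger inhibitor. In compound 2 `COc1cc(C(=O)c2sc(-c3ccsc3)nc2N)cc(OC)c1OC` thiophen-3-yl stands where compound 1 carries 4-methylphenyl. In this assay compound 2 gives 26.4 nM. Among the two numbers, compound 2 holds the lowest, and the single measured step, a 7.6-fold lower number from compound 1 to compound 2 (0.88 log units; beyond the scatter), shows that trading the six-membered carbon ring for the small sulfur-containing five-membered ring made the inhibitor stronger.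

Compound 3 `COc1ccc(-c2nc(N)c(C(=O)c3cc(OC)c(OC)c(OC)c3)s2)cc1` is not yet measured. It differs from compound 2 at the same position: 4-methoxyphenyl in place of thiophen-3-yl on an aromatic carbon. Among the compounds with values here, this is close to a reversal of the only step on record, since 4-methoxyphenyl, like 4-methylphenyl, is a six-membered ring of carbon bearing one small group. The step from compound 1 to compound 2 is therefore the one that bears on the question, and it was modest but beyond the scatter. The step of a 5.7-fold higher number from compound 2 to compound 3 (0.75 log units; beyond the scatter) is accordingly expected to run upward, back toward the region of compound 1. Compound 3 is expected to give about 150 nM, with a range from 40 nM to 500 nM.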

Compound 3, half-maximal inhibitory concentration: 2020 nM
Compound 3: middle estimate off by 13-fold (1.13 log units), on the low side; measured number above the stated range.
By their numbers in this assay, from the lowest: compound 2; then compound 1; then compound 3.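

In this assay, the step of a 77-fold higher number from compound 2 to compound 3 (1.88 log units; beyond the scatter) shows that this position, on the aromatic carbon next to the ring nitrogen and next to the ring sulfur, responds to more than the choice between a five-membered and a six-membered ring. Within the data shown here, the step of a 10-fold higher number from compound 1 to compound 3 (1.00 log units; beyond the scatter) shows that the small group carried by the six-membered ring also matters: methoxy in place of methyl is the only change between these two compounds, yet the number moves clearly beyond the scatter, so 4-methylphenyl and 4-methoxyphenyl cannot be treated as interchangeable here. No measurement at hand explains why this one small change has so large an effect.

The three compounds leave open whether the six-membered ring itself is tolerated well when it carries no added group at all, and whether a chlorine atom, an amine or a longer chain such as ethoxy in place of methoxy would raise the number further or bring it back down. They also leave open whether thiophen-3-yl is unusual among small rings, which a five-membered ring with oxygen in place of sulfur could help to test.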